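Methyl for Hydroxy on the Fused Ring of Compound 1

The compounds below may be only part of what the source reports. "The series", "measured", "known", "first", "only" and "open" are said of these compounds alone.

Of the compounds shown here, three have been measured in a functional assay on Urethra for agonist activity at Alpha-1A adrenergic receptor (Oryctolagus cuniculus); on this read-out lower numbers stand for lower potency and higher numbers for higher potency (the scale is a negative logarithm). Compound 1 `CS(=O)(=O)Nc1ccc(O)c2c1CCCC2c1c[nH]cn1` gives 4.61, and on this read-out compound 1 stands lowest of the three. The nearest is compound 2 `CS(=O)(=O)Nc1cccc2c1CCCC2C1=NCCN1`, which in this assay gives 6.19, a gap that lies beyond the usual scatter. The furthest is compound 3 `CCS(=O)(=O)Nc1cccc(Cc2c[nH]cn2)c1`, which in this assay gives 6.22, again beyond the scatter. Compound 2 and compound 3 thus sit well above compound 1, while their own two values lie within the scatter of each other.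

Compound 4 `Cc1ccc(NS(C)(=O)=O)c2c1C(c1c[nH]cn1)CCC2` has not yet been measured. It differs from compound 1 in one place: methyl in place of hydroxy on an aromatic carbon. Nothing among the measured compounds traces exactly this exchange, since compound 2 and compound 3 each differ from compound 1 in more than this one spot, so the size of the step cannot be read directly from the numbers shown.

Given that compound 1 holds the lowest value and the two other compounds sit higher, compound 4 is expected to move upward by a moderate step in this assay, beyond the scatter but not reaching the level of compound 2. The expected step is a number 0.69 log units higher from compound 1 to compound 4 (beyond the scatter). Compound 4 is therefore estimated at 5.3, within a range from 4.5 to 6.1.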

Compound 4, negative logarithm of the half-maximal effective concentration: 4.4
The estimate for compound 4 lay 0.90 log units above the measured number, and the stated range ends above it.
By their numbers in this assay, from the lowest: compounds 4 and 1 (each within the scatter of the next); then compounds 2 and 3 (each within the scatter of the next).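

In this assay, within the data shown here, placing methyl in place of hydroxy on the aromatic carbon para to a methanesulfonamido group gives a number 0.21 log units lower from compound 1 to compound 4 (within the scatter), the first direct reading of any change at this position. Hydroxy takes a hydrogen-bond donor and a hydrogen-bond acceptor with it and methyl brings neither, yet compound 1 and compound 4 stand within the scatter of each other, so on this read-out the hydroxy group is not required to keep the number at the level of compound 1. Nothing shown here gives a measured reason for this result.

Going by these compounds, whether an amine, a methoxy group or a longer chain such as ethyl on this same aromatic carbon would also stay within the scatter of compound 1 remains open. The compounds shown also leave open whether the exchange of hydroxy for methyl would read the same way on the core of compound 2 or on that of compound 3, since this one pair is the only place where the change can be followed.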